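From a 4-Methoxyphenyl Amide to an Isobutyl Amide

The source may report more compounds than this note shows. Statements on the series, on what has been measured and on what is new or still open speak of the compounds shown alone.

Going by the values given here, only two compounds have numbers so far in a functional assay on A2780 cells (Homo sapiens) for inhibition, read by sulforhodamine B assay, with a stated time of 3 days (on this read-out higher numbers stand for weaker inhibition and lower numbers for stronger inhibition), and their numbers cannot be told apart. Compound 1 `O=C1Nc2ccc([N+](=O)[O-])cc2/C1=C\C(=O)c1ccc(C2CCCCC2)cc1` gives 2090 nM as its half-maximal inhibitory concentration, and compound 2 `COc1ccc(C(=O)Nc2ccc3c(c2)/C(=C/Nc2cccc(N4CCN(C)CC4)c2)C(=O)N3)cc1` gives 2050 nM there, so compound 2 stands within the usual scatter of compound 1.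

Compound 3 `CC(C)CC(=O)Nc1ccc2c(c1)/C(=C/Nc1cccc(N3CCN(C)CC3)c1)C(=O)N2` keeps the core of compound 2 and alters one group, with isobutyl in place of 4-methoxyphenyl on a carbonyl carbon. Among the compounds with values here, no two measured compounds differ in just one place, so the data offer no direct guide to this swap. The expectation therefore starts from compound 2 at 2050 nM in this assay and assumes no shift beyond the scatter in either direction. The expected change is a 1.0-fold lower number from compound 2 to compound 3 (0.01 log units; within the scatter) on these numbers. For compound 3 the estimated value is 2000 nM with a wide likely range from 600 nM to 6500 nM at this stage.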

Compound 3, half-maximal inhibitory concentration: 3370 nM
Beside the measured number, compound 3's estimate is 1.7-fold (0.23 log units) below it; low and high end bracket the measured number.
By their numbers in this assay, from the lowest: compounds 2, 1 and 3 (each within the scatter of the next).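

Going by these compounds alone, this is the first pair here that differs in only one place, so the group on the carbonyl carbon can now be read directly in this assay: replacing 4-methoxyphenyl with isobutyl gives a 1.6-fold higher number from compound 2 to compound 3 (0.22 log units; within the scatter). On this one pair, a group with 8 heavy atoms and an aromatic ring gives way to one with 4 heavy atoms and no ring, and the number stays within the scatter. Nothing given here speaks to the reason for this result.

Still open, on these data alone, is whether this place tolerates other groups, such as a longer chain, an amine or a carboxylic acid on the same carbonyl carbon. A single pair also cannot show whether the same swap would behave alike on a different core.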